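Cytotoxicity on changing the group on an aromatic nitrogen

The source may report more compounds than this note shows. Statements on the series, on what has been measured and on what is new or still open speak of the compounds shown alone.

Measured so far in an ADME assay on HOS cells (Homo sapiens) for cytotoxicity (a higher number here means that more compound is tolerated, a lower number that less compound is tolerated), are these values:
- compound 1 `CN1CCC(n2c(CN(C)C3CCCc4cccnc43)nc3ccccc32)CC1` gives 16000 nM here
- compound 2 `CN1CCC[C@H](Cn2c(CN(C)[C@@H]3CCCc4cccnc43)nc3ccccc32)C1` gives 3600 nM here
- compound 3 `CC(C)CCN1CCC[C@H](Cn2c(CN(C)[C@H]3CCCc4cccnc43)nc3ccccc32)C1` gives 2300 nM here

Compound 1 holds the highest of the three numbers, and both other compounds lie lower, beyond the scatter. Compound 4 `CN1CCCCC1CCn1c(CN(C)C2CCCc3cccnc32)nc2ccccc21` carries 2-(1-methylpiperidin-2-yl)ethyl in place of 1-methylpiperidin-4-yl on an aromatic nitrogen. For the measured compounds named here, no measured pair isolates this change. Compound 2 (3600 nM) and compound 3 (2300 nM) also differ from compound 1 in the group on that nitrogen, so a move towards their level seems likely. The expected step is a 2.7-fold lower number from compound 1 to compound 4 (0.43 log units; beyond the scatter) in the downward direction. Compound 4 is estimated at 6000 nM with an expected range from 2500 nM to 16000 nM as the likely span.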

Compound 4, half-maximal cytotoxic concentration: 4900 nM
Estimate against measurement, compound 4: 1.2-fold (0.09 log units) above; low and high end bracket the measured number.
By their numbers in this assay, from the lowest: compounds 3, 2 and 4 (each within the scatter of the next, the first and the last beyond it); then compound 1.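

In this assay, 2-(1-methylpiperidin-2-yl)ethyl in place of 1-methylpiperidin-4-yl on the aromatic nitrogen gives a 3.3-fold lower number from compound 1 to compound 4 (0.51 log units; beyond the scatter), the only step shown that isolates a change at this position. Both groups hold one six-membered non-aromatic ring with 1 hetero atom, yet they differ in size, 9 heavy atoms against 7, and in how the ring is attached. Nothing given here explains the step.

On these data alone, it remains open whether the chain length or the ring attachment carries the step. A 1-methylpiperidin-2-ylmethyl group or an unmethylated piperidin-4-yl group could help separate these.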